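The source may hold more compounds than are shown below. What is called first, only, known or untested is meant among the compounds shown, and "the series" means these compounds.

Measured compounds:
- compound 1, `COC(=O)C1=C(C)NC(C)=C(C(=O)OC)C1c1ccc(-c2cc(=O)cc(-c3ccccc3)o2)cc1`, 4710 nM
- compound 2, `COC(=O)C1=C(C)NC(C)=C(C(=O)OC)C1c1ccc(-c2cc(=O)cc(C)o2)cc1`, 17800 nM
- compound 3, `CCOC(=O)C1=C(C)NC(C)=C(C(=O)OCC)C1c1cc(=O)cc(-c2ccccc2)o1`, 3240 nM

These three compounds were tested in an assay on isolated protein (strain albino) for inhibition of Voltage-dependent L-type calcium channel subunit alpha-1C (Cavia porcellus); a higher number here means a weaker inhibitor, a lower number a stronger inhibitor. In this assay compound 1 stands second highest of the three numbers. Its nearest neighbour is compound 3, whose value is within the scatter of that of compound 1, so no order can be read between them. Among the compounds with values here, the only counted step is a 3.8-fold higher number from compound 1 to compound 2 (0.58 log units; beyond the scatter), a modest change in the direction of weaker inhibition.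

Compound 4, `CCOC(=O)C1=C(C)NC(C)=C(C(=O)OC)C1c1ccc(-c2cc(=O)cc(-c3ccccc3)o2)cc1`, differs from compound 1 by methyl in place of hydrogen on a saturated chain carbon bound to an oxygen next to a carbonyl group. Within the data shown here, no measured step bears on this change: the step from compound 1 to compound 2 concerns a different part of the molecule, and compound 3 carries two ethyl esters together with a different core attachment, so it offers no clean comparison. With nothing in the data pointing either way, compound 4 is expected to show a 1.1-fold lower number from compound 1 to compound 4 (0.04 log units; within the scatter), a step within the scatter. The estimate for compound 4 is therefore 4300 nM, with a range from 1800 nM to 10000 nM.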

Compound 4, half-maximal inhibitory concentration: 94400 nM
Beside the measured number, compound 4's estimate is 22-fold (1.34 log units) below it; measured number outside the range, above it.
By their numbers in this assay, from the lowest: compounds 3 and 1 (each within the scatter of the next); then compound 2; then compound 4.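

In this assay, the methoxycarbonyl to ethoxycarbonyl change proved far from silent: methyl in place of hydrogen on a saturated chain carbon bound to an oxygen next to a carbonyl group gave a 20-fold higher number from compound 1 to compound 4 (1.30 log units; beyond the scatter) in the direction of weaker inhibition. Before this result, the only counted change was the swap of phenyl for methyl on an aromatic carbon, which gave a 3.8-fold higher number from compound 1 to compound 2 (0.58 log units; beyond the scatter) and was graded modest, whereas this addition of a single carbon is graded large. Nothing available explains the size of this step.

The compounds shown leave open whether a longer chain in place of the ethyl, or a carboxylic acid in place of the ethoxycarbonyl, would give a weaker or stronger inhibitor. They also leave open whether ethoxycarbonyl in place of the second methoxycarbonyl would add a further step.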